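Methylsulfanyl for Methoxy on Two Related Cores

A few compounds are considered here, and "the series" means these few. Any claim that something is new, unique, unknown or untested is made for them only; others in the source may bear on it.

Compound 1 `CSc1ccc(CNc2nc(SC)nc3ncccc23)cc1` and compound 2 `COc1ccc(CNc2nc(SC)nc3ncccc23)cc1` share one core, while compound 3 `COc1ccc(CNc2nc(SC)nc3ccccc23)cc1` and compound 4 `CSc1ccc(CNc2nc(SC)nc3ccccc23)cc1` share another; the difference between the two cores is not broken down here. In a functional assay on HTB-54 cells (Homo sapiens) for cytotoxicity, read by MTT assay, with a stated time of 72 h (on this read-out lower numbers stand for stronger inhibition of growth and higher numbers for weaker inhibition of growth), compound 1 gives 3280 nM. For compound 2 the assay reports only a limit, > 100000 nM, which is the limit of > 100000 nM in this assay, at which 1 of the 3 values shown sits. The change from compound 2 to compound 1 is methylsulfanyl in place of methoxy on an aromatic carbon, and it gives an at least 30-fold lower number from compound 2 to compound 1 (1.48 log units; beyond the scatter). In this assay compound 3 gives 93700 nM. The change from compound 3 to compound 4 is methylsulfanyl in place of methoxy on an aromatic carbon, the same change made on the other core. Compound 4 is expected to show a step of a 31-fold lower number from compound 3 to compound 4 (1.49 log units; beyond the scatter), an expectation resting on compound 1 and the step of an at least 30-fold lower number from compound 2 to compound 1 (1.48 log units; beyond the scatter). The estimate for compound 4 is 3000 nM, expected between 800 nM and 15000 nM.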

Compound 4, concentration for 50% growth inhibition: 7220 nM
Compound 4: the middle estimate sits 2.4-fold (0.38 log units) below what was measured, and the stated range covers the measured number.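

In this assay, methylsulfanyl in place of methoxy on an aromatic carbon again gives a large change on the second core, a 13-fold lower number from compound 3 to compound 4 (1.11 log units; beyond the scatter). Set beside the earlier step, the change goes the same way on both cores: the same change on two cores in this assay, an at least 30-fold lower number (1.48 log units; beyond the scatter) from compound 2 to compound 1 and a 13-fold lower number (1.11 log units; beyond the scatter) from compound 3 to compound 4; the limit leaves it open whether they differ Compound 2 has a limit and not a number, so the data show that the direction carries over but not that the size does: the limit of > 100000 nM in this assay, at which 1 of the 4 values shown sits.

The compounds shown leave open how an ethylsulfanyl group, an amine or a chlorine would compare with methylsulfanyl in the same place. They also leave open whether the change would go the same way on any core other than these two.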